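A Phenyl for Bromo Swap Across Two Cores

This account rests on a few compounds, and the source may have more. Where it says the series, first, only, none or still open, it means among the compounds named here.

Compound 1 `O=C(N1CCC=C[C@@H]1COCc1ccccc1)n1cc(-c2ccc(-c3ccccc3)cc2)nn1` and compound 2 `O=C(N1CCC=C[C@@H]1COCc1ccccc1)n1cc(-c2ccc(Br)cc2)nn1` share one core and differ only at one aromatic carbon. In an assay on HEK293 cells for inhibition of Monoacylglycerol lipase ABHD6 (Homo sapiens), read by fluorescence (a lower number here means a stronger inhibitor, a higher number a weaker inhibitor), compound 1 gives 12.6 nM. In this assay compound 2 gives 15.9 nM. The change between them is phenyl in place of bromo on an aromatic carbon, and it made a 1.3-fold lower number from compound 2 to compound 1 (0.10 log units; within the scatter), so the two values cannot be told apart.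

Compound 3 `O=C(N1CCC=C[C@@H]1COCc1ccccc1)n1ccc(-c2ccc(Br)cc2)n1` carries the same bromophenyl substituent as compound 2 but on a different core; the difference between the two cores is not broken down here. In this assay compound 3 reaches only (the limit of > 10000 nM in this assay, at which 1 of the 3 values shown sits), so its result is a limit rather than a number. That limit for compound 3 stands as > 10000 nM.

Compound 4 `O=C(N1CCC=C[C@@H]1COCc1ccccc1)n1ccc(-c2ccc(-c3ccccc3)cc2)n1` has not yet been measured in this assay. It stands to compound 3 as compound 1 stands to compound 2, by the change (phenyl in place of bromo on an aromatic carbon), the same change in the same place. Because that change on the other core gave a 1.3-fold lower number from compound 2 to compound 1 (0.10 log units; within the scatter), the change on the core of compound 3 is also expected to move the number little, a step that the limit leaves unreadable from compound 3 to compound 4, which leaves compound 4 near the limit. Compound 4 is therefore expected to give about 15000 nM, with the estimate spanning 3000 nM to 50000 nM.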

Compound 4, half-maximal inhibitory concentration: > 10000 nM
Compound 4: a limit, no number; the forecaster's own chance of this, stated with the estimate: 70%; the middle value does not contradict the limit.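

In this assay compound 4 gives > 10000 nM as a limit and not a number. Compound 3 also stands at a limit, so no step can be read between compound 3 and compound 4, and both share one ceiling: the limit of > 10000 nM in this assay, at which 2 of the 4 values shown sit.

The compounds shown leave open how far compound 3 and compound 4 lie beyond that limit, and whether phenyl in place of bromo changes anything on their core.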